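Chromone aryl ether series: amine chain enters at compound 4

The source may hold more compounds than are shown below. What is called first, only, known or untested is meant among the compounds shown, and "the series" means these compounds.

compound 1 `COc1cc(OC)c2c(=O)cc(-c3ccc(OC4CCN(C)CC4)cc3)oc2c1`: 49%
compound 2 `COc1cc(OC)c2c(=O)cc(-c3ccc(OCCCN(C)C)cc3)oc2c1`: 59%
compound 3 `COc1cc(OC)c2c(=O)cc(-c3ccc(OCC(O)CO)cc3)oc2c1`: 11%

In a functional assay (Homo sapiens) for antiproliferative activity, read by resazurin assay, with a stated time of 48 h, tested at 10 uM (a higher number here means a stronger effect of the compound at the concentration tested, a lower number a weaker effect), compound 3 stands lowest of the three numbers; compound 1 is nearest, compound 2 furthest, and both steps, a number 38 percentage points lower from compound 1 to compound 3 (beyond the scatter) and a number 48 percentage points lower from compound 2 to compound 3 (beyond the scatter), are large. Compound 4 `COc1cc(OC)c2c(=O)cc(-c3ccc(NCCN4CCCC4)cc3)oc2c1` differs from compound 3 by (2-(pyrrolidin-1-yl)ethyl)amino in place of 2,3-dihydroxypropoxy on an aromatic carbon. The two large steps into compound 3 both ran downward when 1-methylpiperidin-4-yl or 3-(dimethylamino)propyl gave way to 2,3-dihydroxypropyl; the change to compound 4 runs the other way, and the step of a number 10 percentage points higher from compound 1 to compound 2 (within the scatter) shows those two earlier groups sit at one level. A large upward step is therefore expected in this assay, a number 41 percentage points higher from compound 3 to compound 4 (beyond the scatter). Compound 4 is estimated at 52%, with a range of 32% to 72%.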

Compound 4, a percentage reported as inhibition, at one concentration (the size of the read-out at that concentration, not a potency): 51%
For compound 4 the middle estimate is 1 percentage points above the measured one, and the stated range covers the measured number.
By their numbers in this assay, from the lowest: compound 3; then compounds 1, 4 and 2 (each within the scatter of the next).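

In this assay, (2-(pyrrolidin-1-yl)ethyl)amino on this aromatic carbon recovers the loss seen with 2,3-dihydroxypropoxy, with a number 40 percentage points higher from compound 3 to compound 4 (beyond the scatter) as the large step. An ether oxygen at this position is therefore not required to reach the level of the two earlier amine-bearing compounds, as a number 8 percentage points lower from compound 2 to compound 4 (within the scatter) and a number 2 percentage points higher from compound 1 to compound 4 (within the scatter) both stay within the scatter.

Compound 4 changes the linking atom and the terminal amine together, so a morpholine on the same amino chain, or a longer chain, would be needed to separate the two. No supporting data bear on the reason for this result.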